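The source may report more compounds than this note shows. Statements on the series, on what has been measured and on what is new or still open speak of the compounds shown alone.

Compound 3 `NC(=O)N1CCN(C(=S)SCc2cn(Cc3ccc(F)cc3)nn2)CC1` gives 22100 nM in a functional assay on MCF7 cells (Homo sapiens) for cytotoxicity, read by MTT assay, with a stated time of 72 h (on this read-out higher numbers stand for weaker inhibition and lower numbers for stronger inhibition), the highest of the two numbers shown. Its nearest neighbour on that read-out is compound 2 `CCNC(=O)N1CCN(C(=S)SCc2cn(Cc3ccccc3F)nn2)CC1`, which gives 5760 nM in this assay. Compound 1 `NC(=O)N1CCN(C(=S)SCc2cn(Cc3ccccc3F)nn2)CC1` reaches only a limit of the assay, > 128000 nM in this assay. Compound 4 `CCNC(=O)N1CCN(C(=S)SCc2cn(Cc3ccc(F)cc3)nn2)CC1` is not yet measured; it differs from compound 3 in one place: ethyl in place of hydrogen on an amide-type nitrogen. The same change has been measured once before, from compound 1 to compound 2, where it gave an at least 22-fold lower number from compound 1 to compound 2 (1.34 log units; beyond the scatter) in this assay, a large drop whose full size is hidden by the limit of > 128000 nM in this assay, at which 1 of the 3 values shown sits. Compound 3 itself stands apart from compound 1 by an at least 5.7-fold lower number from compound 1 to compound 3 (0.76 log units; beyond the scatter) in this assay, so the ethyl step starts here from a number already well within the measurable range. A large fall is therefore expected in this assay. Compound 4 is estimated at 1200 nM, in a range from 300 nM to 5000 nM. That estimate corresponds to an expected step of an 18-fold lower number from compound 3 to compound 4 (1.27 log units; beyond the scatter).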

Compound 4, half-maximal inhibitory concentration: 3660 nM
The estimate for compound 4 lay 3.1-fold (0.48 log units) below the measured number; low and high end bracket the measured number.
By their numbers in this assay, from the lowest: compounds 4 and 2 (each within the scatter of the next); then compound 3. At a limit, above all of these: compound 1.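

The ethyl step keeps its direction on the 4-fluorophenyl pair, with a 6.0-fold lower number from compound 3 to compound 4 (0.78 log units; beyond the scatter) in this assay, but its size depends on which fluorophenyl group the compound carries: the same change on two cores in this assay, an at least 22-fold lower number (1.34 log units; beyond the scatter) from compound 1 to compound 2 and a 6.0-fold lower number (0.78 log units; beyond the scatter) from compound 3 to compound 4, at least 3.6-fold (0.56 log units) apart, beyond the scatter of two such steps. Within the data shown here, with ethylcarbamoyl in place, the choice between 2-fluorophenyl and 4-fluorophenyl no longer separates the compounds, with a 1.6-fold lower number from compound 2 to compound 4 (0.20 log units; within the scatter), although it did separate the carbamoyl pair: the same change on two cores in this assay, an at least 5.7-fold lower number (0.76 log units; beyond the scatter) from compound 1 to compound 3 and a 1.6-fold lower number (0.20 log units; within the scatter) from compound 2 to compound 4, at least 3.6-fold (0.56 log units) apart, beyond the scatter of two such steps. As far as these compounds go, both gaps rest on compound 1, whose > 128000 nM is a limit of the assay, so their true size remains unknown.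

The compounds shown leave open how a propyl chain or a 2-hydroxyethyl group on the amide-type nitrogen would compare with ethyl. They also leave open how a plain phenyl or a 3-fluorophenyl group would read in this assay with either hydrogen or ethyl on that nitrogen.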